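The source may hold more compounds than are shown below. What is called first, only, known or untested is meant among the compounds shown, and "the series" means these compounds.

Compound 1 `O=C(/C=C/c1ccc(OCCCCCO[N+](=O)[O-])c(O)c1)OCCCCCO[N+](=O)[O-]`: > 50000 nM (a limit)
Compound 2 `O=C(/C=C/c1ccc(O)c(O)c1)OCc1c(-c2ccccc2)no[n+]1[O-]`: 12500 nM

Both compounds were tested in a functional assay on M14 cells (Homo sapiens) for cytotoxicity, read by resazurin assay, with a stated time of 72 h; a higher number here means a weaker inhibitor, a lower number a stronger inhibitor. The entry for compound 1, > 50000 nM, is a limit of the assay and not a number. Within the data shown here, compound 2, at 12500 nM, therefore provides the only actual number in this small set.

Compound 3 `COc1cc(/C=C/C(=O)OCc2c(-c3ccccc3)no[n+]2[O-])ccc1O` has not yet been measured. It differs from compound 2 by methyl in place of hydrogen on an oxygen on an aromatic ring, with methyl in place of hydrogen on an oxygen on an aromatic ring, so that 3,4-dihydroxyphenyl becomes 4-hydroxy-3-methoxyphenyl. Among the measured compounds shown here, no measured pair shows what this change does, so the expectation rests only on compound 2 at 12500 nM. The estimated 1.6-fold higher number from compound 2 to compound 3 (0.20 log units; within the scatter) is expected to be small, tilting towards weaker inhibition and perhaps staying within the usual scatter. In this assay, the estimate for compound 3 is 20000 nM, expected to lie between 8000 nM and 50000 nM.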

Compound 3, half-maximal inhibitory concentration: 14000 nM
Beside the measured number, compound 3's estimate is 1.4-fold (0.15 log units) above it, within the range that was stated.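

Placing methyl on an oxygen on an aromatic ring, which turns 3,4-dihydroxyphenyl into 4-hydroxy-3-methoxyphenyl, gives in this assay a 1.1-fold higher number from compound 2 to compound 3 (0.05 log units; within the scatter). Among these compounds, this is the first reading of any change at this position, and it shows that hydroxy and methoxy there cannot be told apart in this pair. Compound 1 remains a limit of the assay and not a number, and steps involving it cannot be read: the limit of > 50000 nM in this assay, at which 1 of the 3 values shown sits.

The compounds shown leave open whether ethyl on this same oxygen would also leave the value within the scatter, or whether a larger change would move it. They also do not show what an amine in place of this hydroxy would do, or whether methyl on the other oxygen of the 3,4-dihydroxyphenyl group would give a similar result.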